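From thiazole to bromomethylthiophene in a benzylamine series

The source may report more compounds than this note shows. Statements on the series, on what has been measured and on what is new or still open speak of the compounds shown alone.

Compound 1 `Clc1ccc(CN(Cc2cccnc2)Cc2nccs2)cc1` is the reference here. In an assay on isolated protein for agonist activity at nuclear receptor subfamily 1 group D member 1 (Homo sapiens), read by FRET, with a stated time of 1 h (on this read-out lower numbers stand for an effect already at smaller amounts and higher numbers for an effect only at larger amounts of compound), compound 1 gives only a limit of the assay, > 50000 nM (the limit of > 50000 nM in this assay, at which 1 of the 2 values shown sits). The related compound 2 `Clc1ccc(CN(Cc2cccnc2)Cc2cc3ccccc3s2)cc1` gives 400 nM in this assay. The step to compound 3 `Cc1sc(CN(Cc2ccc(Cl)cc2)Cc2cccnc2)cc1Br` places 4-bromo-5-methylthiophen-2-yl in place of 1,3-thiazol-2-yl on a saturated chain carbon bound to an amine nitrogen. Within the data shown here, no measured step covers this change, so the expectation rests on compound 2 alone: a gain beyond the scatter is expected, with the estimated step from compound 1 to compound 3 being an at least 10-fold lower number from compound 1 to compound 3 (1.00 log units; beyond the scatter). Compound 3 is expected to give 5000 nM, estimated between 1000 nM and 50000 nM.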

Compound 3, half-maximal effective concentration: 250 nM
Compound 3: middle estimate off by 20-fold (1.30 log units), on the high side; measured number below the stated range.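

In this assay, 4-bromo-5-methylthiophen-2-yl in place of 1,3-thiazol-2-yl on a saturated chain carbon bound to an amine nitrogen brings an at least 200-fold lower number from compound 1 to compound 3 (2.30 log units; beyond the scatter). Among these compounds, this is the first measured step at this position, and it shows that a change confined to this one five-membered aromatic ring can decide the read-out. The value of compound 1 is a limit of the assay, so the full size of the step stays unknown: the limit of > 50000 nM in this assay, at which 1 of the 3 values shown sits.

As far as these compounds go, whether the bromine, the methyl or the exchange of thiazole for thiophene carries the gain remains open. So does how an unsubstituted thiophen-2-yl or a carboxylic acid on that ring would read.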